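Halogen Exchange at the Aromatic Ring of Compound 2

The source may report more compounds than this note shows. Statements on the series, on what has been measured and on what is new or still open speak of the compounds shown alone.

Compound 1 `C1=NCC(CC2=Cc3ccccc3CC2)N1` gives 50.1 nM in a functional assay for binding affinity to Norepinephrine transporter (Rattus norvegicus), read by radioligand binding, in the presence of a further agent that is not named here (a lower number here means a stronger inhibitor, a higher number a weaker inhibitor), and compound 2 `Clc1cccc2c1C=C(CC1CN=CN1)CC2` gives 50.1 nM. The step of no change at the digits printed from compound 1 to compound 2 (within the scatter) shows that the chloro group of compound 2 leaves the affinity where compound 1 has it, so compound 2 stands level with compound 1. Compound 3 `Fc1cccc2c1C=C(CC1CN=CN1)CC2` carries the change (fluoro in place of chloro on an aromatic carbon). For the measured compounds named here, the only measured step that bears on this position left the affinity unchanged, so no step beyond the scatter is expected here either. Compound 3 is therefore estimated at 50 nM, between 25 nM and 100 nM, a step of a 1.0-fold lower number from compound 2 to compound 3 (0.00 log units; within the scatter) from compound 2.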

Compound 3, inhibition constant: 126 nM
Compound 3: middle estimate off by 2.5-fold (0.40 log units), on the low side; measured number outside the range, above it.
By their numbers in this assay, from the lowest: compounds 1 and 2 (each within the scatter of the next); then compound 3.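

In this assay fluoro in place of chloro gives a 2.5-fold higher number from compound 2 to compound 3 (0.40 log units; beyond the scatter) and fluoro in place of hydrogen gives a 2.5-fold higher number from compound 1 to compound 3 (0.40 log units; beyond the scatter) so this aromatic carbon does respond to what it carries, which the earlier step alone did not show. Hydrogen and chloro read level here, and fluoro alone stands apart from them. Nothing measured here accounts for that difference.

The compounds shown leave open whether bromo or methoxy on this carbon would read with hydrogen and chloro or with fluoro. They also leave open whether fluoro has the same effect on other aromatic carbons of the shared core.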